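A few compounds are considered here, and "the series" means these few. Any claim that something is new, unique, unknown or untested is made for them only; others in the source may bear on it.

The study follows inhibition in a functional assay on Vero cells (Chlorocebus sabaeus) for inhibition; a higher number here means a weaker inhibitor, a lower number a stronger inhibitor. Compound 1 `Nc1ccn([C@@H]2O[C@@H](CO)C=C2F)c(=O)n1` and compound 2 `Nc1nc(=O)n([C@@H]2O[C@@H](CO)C=C2F)cc1F` share one core, while compound 3 `Nc1nc(F)nc2c1ncn2[C@H]1O[C@@H](CO)C=C1F` and the not yet measured compound 4 `Nc1ncnc2c1ncn2[C@H]1O[C@@H](CO)C=C1F` share another; how the two cores differ is not broken down here. In this assay compound 1 gives only a limit, > 100000 nM. Compound 2 likewise reaches only a limit in this assay, > 100000 nM. Among the compounds with values here, compound 3 is the one compound with a number in this assay, 173000 nM. Going from compound 2 to compound 1 the change is hydrogen in place of fluoro on an aromatic carbon, and its step, a step that the two limits leave unreadable from compound 2 to compound 1, cannot be read because of the limit of > 100000 nM in this assay, at which 2 of the 3 values shown sit. Compound 4 arises from compound 3 by the same kind of change, (hydrogen in place of fluoro on an aromatic carbon), though here the carbon lies in a ring that is part of a fused or bridged system of two rings, between two ring nitrogen atoms, meta to an amino group, and meta and para to a fused ring. The step of a 1.2-fold lower number from compound 3 to compound 4 (0.06 log units; within the scatter) is expected to be small, which rests on every measured compound sitting at or near the limit of this assay. Compound 4 is thus estimated at 150000 nM.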

Compound 4, half-maximal inhibitory concentration: > 100000 nM
Compound 4 was reported as a limit; the forecaster's own chance of this, stated with the estimate: 60%; the middle value is on the limit's open side.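

Compound 4 is reported only as a limit, so the step from compound 3 to compound 4 cannot be read, and no size can be given for it: the limit of > 100000 nM in this assay, at which 3 of the 4 values shown sit. The compounds shown leave open whether hydrogen in place of fluoro on an aromatic carbon changes inhibition at all in this assay, on either core.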